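The compounds below may be only part of what the source reports. "The series", "measured", "known", "first", "only" and "open" are said of these compounds alone.

Series notes. Compound 1 `O=C(NCc1ccccc1)c1cn(-c2ccccc2)nc1-c1cccnc1` in a functional assay on HL-60 cells (Homo sapiens) for cytotoxicity, read by MTT assay, with a stated time of 48 h (on this read-out lower numbers stand for stronger inhibition and higher numbers for weaker inhibition), gives "nd(insoluble)" (no result reported), with no number reported. Compound 2 `COc1ccc(OC(=O)c2cn(-c3ccccc3)nc2-c2cccnc2)cc1` returns only a limit in this assay, > 100000 nM. Compound 3 `CC(C)(C)c1ccc(OC(=O)c2cn(-c3ccccc3)nc2-c2cccnc2)cc1` likewise returns only a limit in this assay, > 100000 nM. For the measured compounds named here, the single step within the measured pair, a step that the two limits leave unreadable from compound 2 to compound 3, cannot be read because of the limit of > 100000 nM in this assay, at which 2 of the 3 values shown sit. Compound 4 `Cc1ccc(C(C)C)c(OC(=O)c2cn(-c3ccccc3)nc2-c2cccnc2)c1` carries the change (2-isopropyl-5-methylphenyl in place of 4-methoxyphenyl on an oxygen next to a carbonyl group). Going by the values given here, no readable measured step bears on this change; the one neighbouring step is itself unreadable. Compound 4 is therefore expected to sit at or near the same limit, the expected step being a step that the limit leaves unreadable from compound 2 to compound 4. The estimate for compound 4 in this assay is 150000 nM, with a range from 40000 nM to 600000 nM.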

Compound 4, half-maximal inhibitory concentration: 22700 nM
The estimate for compound 4 lay 6.6-fold (0.82 log units) above the measured number; the whole stated range lies above it.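

The group on an oxygen next to a carbonyl group can move the number in this series: 2-isopropyl-5-methylphenyl in place of 4-methoxyphenyl gives an at least 4.4-fold lower number from compound 2 to compound 4 (0.64 log units; beyond the scatter), and in place of 4-(tert-butyl)phenyl it gives an at least 4.4-fold lower number from compound 3 to compound 4 (0.64 log units; beyond the scatter). Compound 4 is the first compound shown with a number rather than a limit in this assay. Both steps are only lower bounds because the earlier compounds stop at a limit: the limit of > 100000 nM in this assay, at which 2 of the 4 values shown sit.

Whether the isopropyl or the methyl group accounts for the step remains open. Also open, on these data alone, is how a phenyl group carrying an amine or a carboxylic acid would read at this place.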